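This account rests on a few compounds, and the source may have more. Where it says the series, first, only, none or still open, it means among the compounds named here.

Working notes on the series in an assay for inhibition of serine/threonine-protein kinase 4 (Homo sapiens), read by luminescence and ADP-Glo, in the presence of a further agent that is not named here; a higher number here means a weaker inhibitor, a lower number a stronger inhibitor.

Compound 1 `Clc1cccc(-c2c[nH]c3ncnc(NCC4CC4)c23)c1` gives 140 nM in this assay. Compound 2 `OC1CCN(c2ncnc3[nH]cc(-c4cccc(Cl)c4)c23)CC1`, which carries 4-hydroxypiperidin-1-yl in place of (cyclopropylmethyl)amino on an aromatic carbon, gives 80 nM; the step of a 1.8-fold lower number from compound 1 to compound 2 (0.24 log units; within the scatter). Compound 3 `CC(=O)NC1CCN(c2ncnc3[nH]cc(-c4cccc(Cl)c4)c23)CC1` gives 26 nM, and the step of a 3.1-fold lower number from compound 2 to compound 3 (0.49 log units; beyond the scatter).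

Within the data shown here, on the three numbers so far, compound 2 stands second highest: its nearest neighbour is compound 1, whose number is higher by an amount within the scatter, and its furthest is compound 3, whose number is lower by an amount beyond the scatter.

The next compound is compound 4 `Clc1cccc(-c2c[nH]c3ncnc(N4CCCCC4)c23)c1`. Against compound 2 the change is hydrogen in place of hydroxy on a saturated ring carbon. Among the measured compounds shown here, the only measured step at that saturated ring carbon is the one from compound 2 to compound 3, where a larger group took the place of hydroxy and the number fell modestly. For the measured compounds named here, no measured step removes the group altogether, so the direction is uncertain; the step from compound 1 to compound 2 touched a different part of the molecule and stayed within the scatter. A small step is expected, most likely toward a somewhat higher number, and the expected step of a 1.6-fold higher number from compound 2 to compound 4 (0.21 log units; within the scatter) is therefore modest at most. For compound 4 the estimate in this assay is 130 nM, with a range from 50 nM to 350 nM.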

Compound 4, half-maximal inhibitory concentration: 48 nM
The estimate for compound 4 lay 2.7-fold (0.43 log units) above the measured number; measured number outside the range, below it.
By their numbers in this assay, from the lowest: compounds 3, 4, 2 and 1 (each within the scatter of the next, the first and the last beyond it).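

In this assay, hydrogen in place of hydroxy on the saturated ring carbon leaves compound 4 within the scatter of compound 2 (a 1.7-fold lower number from compound 2 to compound 4 (0.22 log units; within the scatter)), and hydrogen in place of acetamido leaves it within the scatter of compound 3 (a 1.8-fold higher number from compound 3 to compound 4 (0.27 log units; within the scatter)), so neither substituent is required at this carbon for a number in this range. The gap between the hydroxy and acetamido compounds is therefore the only one at this carbon beyond the scatter, and the unsubstituted piperidin-1-yl compound cannot be told apart from either. On the aromatic carbon, piperidin-1-yl in place of (cyclopropylmethyl)amino gives a modest step beyond the scatter (a 2.9-fold lower number from compound 1 to compound 4 (0.46 log units; beyond the scatter)), which the 4-hydroxypiperidin-1-yl comparison had not shown (a 1.8-fold lower number from compound 1 to compound 2 (0.24 log units; within the scatter)).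

Nothing available explains these steps.

As far as these compounds go, whether a primary amine or a carboxylic acid on the saturated ring carbon would move the number beyond the scatter of compound 4 remains open. Also open, from the compounds shown here alone, is whether a longer acyl chain in place of the acetyl of the acetamido group would separate from compound 4.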